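A few compounds are considered here, and "the series" means these few. Any claim that something is new, unique, unknown or untested is made for them only; others in the source may bear on it.

Measured so far:
compound 1, `CCN(CC)c1ccc(NC(=O)c2c(-c3c(Cl)cccc3Cl)noc2C)cc1Cl` — in an assay on isolated protein for binding affinity to growth hormone secretagogue receptor type 1 (Homo sapiens) (on this read-out higher numbers stand for weaker inhibition and lower numbers for stronger inhibition), compound 1 gives > 10000 nM; this is a limit of the assay, not a number (the limit of > 10000 nM in this assay, at which 1 of the 2 values shown sits).
compound 2, `CCN(CC)c1ccc(NC(=O)c2c(-c3ccccc3-c3ccccc3)noc2C)cc1` — in this assay compound 2 gives 1300 nM, the only number in hand.

Compound 3, `CCN(CC)c1ccc(NC(=O)c2c(-c3ccccc3)noc2C)cc1`, is compound 2 with hydrogen in place of phenyl on an aromatic carbon, ortho to a large group. Within the data shown here, no step between measured compounds is available. The expected step is a 3.5-fold higher number from compound 2 to compound 3 (0.54 log units; beyond the scatter), a loss of affinity beyond the scatter. Compound 3 is estimated at 4500 nM, with a range from 1500 nM to 15000 nM.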

Compound 3, half-maximal inhibitory concentration: 8200 nM
Compound 3: middle estimate off by 1.8-fold (0.26 log units), on the low side, within the range that was stated.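

Phenyl at this place counts for affinity: in this assay, hydrogen in its place gives a 6.3-fold higher number from compound 2 to compound 3 (0.80 log units; beyond the scatter), the first step in the series that can be read. The loss is modest, and compound 3 still gives 8200 nM, a number rather than a limit, so affinity does not rest on the phenyl alone. Nothing measured here accounts for this step.

Open, as far as these compounds go, is whether a methyl or a chlorine at this place keeps part of the affinity. Also open, from the compounds shown here alone, is whether a pyridyl ring can stand in for the phenyl.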